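Swapping the isocyanomethyl group for bromine

The compounds below may be only part of what the source reports. "The series", "measured", "known", "first", "only" and "open" are said of these compounds alone.

Measured compounds:
compound 1, `Cc1nc2c(OCc3ccccc3)cccn2c1CCC#N`: 40%
compound 2, `[C-]#[N+]Cc1c(C)nc2c(OCc3ccccc3)cccn12`: 96%

Going by the values given here, in a functional assay on the whole organism with Rattus norvegicus as the target, with a stated time of 4 h, at a dose of 40 mg/kg by the intraperitoneal route (a higher number here means more inhibition at the dose given (going by the name of the read-out), a lower number less inhibition), compound 2 stands highest of the two, with compound 1 the only neighbour, a number 56 percentage points higher from compound 1 to compound 2 (beyond the scatter). Compound 3, `Cc1nc2c(OCc3ccccc3)cccn2c1Br`, differs from compound 2 by one bromine atom in place of a group of 3 heavy atoms (2 carbon, 1 nitrogen; no ring), on an aromatic carbon. Among the compounds with values here, the one measured step shows that altering this substituent can move the read-out far, but no measured step involves bromine, so direction is uncertain. A downward step, a number 36 percentage points lower from compound 2 to compound 3 (beyond the scatter), is expected. Compound 3 is estimated at 60%, between 25% and 95%.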

Compound 3, a percentage reported as inhibition, in the whole organism at one dose (the size of the read-out at that dose, not a potency): 26%
Estimate against measurement, compound 3: 34 percentage points above, within the range that was stated.
By their numbers in this assay, from the lowest: compound 3; then compound 1; then compound 2.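

Bromo on this aromatic carbon gives a number 70 percentage points lower from compound 2 to compound 3 (beyond the scatter) in this assay, and a number 14 percentage points lower from compound 1 to compound 3 (beyond the scatter). So bromo ranks below both chains here, and the size of the drop depends on which chain it replaces: large for isocyanomethyl, modest for 2-cyanoethyl. No measurement available here explains either drop. On these data alone, how an amine, a carboxylic acid or a longer chain on this carbon would read remains open, as does whether chlorine would behave like bromo.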